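Working notes: aryl carbonyl exchange from compound 2 to compound 4

The compounds below may be only part of what the source reports. "The series", "measured", "known", "first", "only" and "open" are said of these compounds alone.

Measured so far in a functional assay on HepG2 cells (Homo sapiens) for inhibition, read by MTT assay, with a stated time of 24 h; a lower number here means a stronger inhibitor, a higher number a weaker inhibitor:
- compound 1 `CCN(CC)c1ccc(/C=N/NC(=O)CNC(=O)c2ccc(F)cc2)c(OCc2ccccc2Cl)c1`: a limit of the assay, > 50000 nM, not a number.
- compound 2 `Cc1ccc(C(=O)NCC(=O)N/N=C/c2ccc(OCc3ccccc3Cl)cc2)cc1`: 28100 nM
- compound 3 `Cc1cc(C)cc(OCC(=O)NCCNC(=O)COc2cc(C)cc(C)c2)c1`: 53200 nM

Compound 2 gives the smaller of the two numbers, yet its gap to compound 3 lies within the scatter of this assay, so the two are not separated. Among the measured compounds shown here, no step between measured compounds differs in one place, and the only evidence is the limit of > 50000 nM in this assay, at which 1 of the 3 values shown sits.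

Compound 4 `O=C(CNC(=O)c1cccnc1Cl)N/N=C/c1ccc(OCc2ccccc2Cl)cc1` differs from compound 2 by 2-chloropyridin-3-yl in place of 4-methylphenyl on a carbonyl carbon. For the measured compounds named here, with no comparable step to draw on, the step of a 1.1-fold higher number from compound 2 to compound 4 (0.03 log units; within the scatter) is expected to stay within the scatter in either direction. Compound 4 is therefore estimated at 30000 nM, between 10000 nM and 100000 nM.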

Compound 4, half-maximal inhibitory concentration: 4700 nM
The estimate for compound 4 lay 6.4-fold (0.81 log units) above the measured number, and the stated range ends above it.
By their numbers in this assay, from the lowest: compound 4; then compounds 2 and 3 (each within the scatter of the next).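

On the carbonyl carbon whose other neighbour is an amide-type nitrogen, the aryl group can change the result: in this assay, 2-chloropyridin-3-yl in place of 4-methylphenyl gives a 6.0-fold lower number from compound 2 to compound 4 (0.78 log units; beyond the scatter) and is the only step shown between compounds differing in one place. This single step gives a direction for one pair and no trend across the series. Nothing measured here bears on what produces this step.

Going by these compounds, whether the ring nitrogen, the chlorine or both carry the step remains open. A pyridin-3-yl without chlorine and a 2-chlorophenyl on the same carbonyl would separate the two.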